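From Propyl to Iodo: One Exchange on Compound 1

This account rests on a few compounds, and the source may have more. Where it says the series, first, only, none or still open, it means among the compounds named here.

Compound 1 `CCCc1ccc(/C=C/C(=O)Nc2ccc3nc(CCC)cc(N)c3c2)cc1` is the weakest of three compounds in a functional assay on HEK293 cells for activation of melanin-concentrating hormone receptor 1 (Homo sapiens), read by inositol phosphate accumulation (on this read-out lower numbers stand for an effect already at smaller amounts and higher numbers for an effect only at larger amounts of compound), where compound 1 gives 3600 nM. Compound 3 `CCCc1cc(N)c2cc(NC(=O)C3CCC(c4ccc(Cl)cc4)CC3)ccc2n1` gives 370 nM in this assay, and compound 2 `CC(C)(C)c1cc(N)c2cc(NC(=O)/C=C/c3ccc(C(F)(F)F)cc3)ccc2n1` gives 29 nM; both numbers lie far below that of compound 1, beyond the scatter.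

Compound 4 `CCCc1cc(N)c2cc(NC(=O)/C=C/c3ccc(I)cc3)ccc2n1` differs from compound 1 in a single place: iodo in place of propyl on an aromatic carbon. Going by the values given here, no measured pair shows this exact exchange, so the expectation rests on the other two compounds, which carry chloro or trifluoromethyl on a phenyl ring and reach lower numbers. Compound 4 is expected to move downward beyond the scatter, by a step of about a 14-fold lower number from compound 1 to compound 4 (1.16 log units; beyond the scatter). Compound 4 is therefore estimated at 250 nM, with a range from 60 nM to 1000 nM.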

Compound 4, half-maximal effective concentration: 280 nM
Compound 4: the middle estimate sits 1.1-fold (0.05 log units) below what was measured; measured number inside the range.
By their numbers in this assay, from the lowest: compound 2; then compounds 4 and 3 (each within the scatter of the next); then compound 1.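

In this assay, the change from 4-propylphenyl to 4-iodophenyl gives a 13-fold lower number from compound 1 to compound 4 (1.11 log units; beyond the scatter) while the rest of the molecule stays the same. Going by these compounds alone, this is the first step that can be read at this position, as the earlier compounds differ from one another in more than one place. Nothing given here accounts for the size of the step.

The compounds shown do not tell whether the step comes from the arrival of iodo or the departure of propyl. They also leave open how an amine, a carboxylic acid or a longer chain would read at this place.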